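The compounds below may be only part of what the source reports. "The series", "measured", "known", "first", "only" and "open" are said of these compounds alone.

Measured so far in a toxicity assay on TZM cells (Homo sapiens) for cytotoxicity, read by XTT assay, with a stated time of 3 days; on this read-out lower numbers stand for higher toxicity in this test and higher numbers for lower toxicity in this test:
- compound 1 `Cc1ccc(-c2ccc(C(=O)N[C@H](c3nc(C)c(CCO)s3)[C@@H]3CCCCN3)[nH]2)cc1F`: 28800 nM
- compound 2 `Cc1ccc(-c2ccc(C(=O)N[C@@H](c3nc(C)c(CCO)s3)[C@@H]3CCCCN3)[nH]2)cc1F`: 15300 nM

Within the data shown here, only two numbers are available, and they do not separate: the one measured step is a 1.9-fold lower number from compound 1 to compound 2 (0.27 log units; within the scatter), which lies within the scatter. Its structural basis is the fact that compounds 1 and 2 differ only in the configuration as drawn. Compound 3 `Cc1nc([C@H](NC(=O)c2ccc(-c3ccc(Cl)cc3)[nH]2)[C@@H]2CCCCN2)sc1CCO` has 4-chlorophenyl in place of 3-fluoro-4-methylphenyl on an aromatic carbon of a five-membered aromatic ring with 1 nitrogen (4-chlorophenyl in place of 3-fluoro-4-methylphenyl on an aromatic carbon). The measured step leaves this group unchanged, so it gives no size or direction for the exchange. No step beyond the scatter is therefore expected in this assay, and the anchor is compound 2 at 15300 nM. The expected step is a 1.1-fold higher number from compound 2 to compound 3 (0.05 log units; within the scatter). Compound 3 is estimated at 17000 nM, with an expected range of 7000 nM to 42000 nM.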

Compound 3, half-maximal cytotoxic concentration: 15400 nM
Compound 3: middle estimate off by 1.1-fold (0.04 log units), on the high side; measured number inside the range.
By their numbers in this assay, from the lowest: compounds 2, 3 and 1 (each within the scatter of the next).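

In this assay, among these compounds, 4-chlorophenyl in place of 3-fluoro-4-methylphenyl on an aromatic carbon, next to the ring nitrogen, gives a 1.0-fold higher number from compound 2 to compound 3 (0.00 log units; within the scatter), the first reading at this position, since the earlier step altered only the configuration as drawn. The two substituted phenyl groups are not told apart in this test, although one carries a chlorine and the other a fluorine and a methyl. Nothing at hand gives a reason for this outcome.

As far as these compounds go, both groups are halogen-bearing phenyl rings, so it remains open whether a phenyl bearing an amine or a carboxylic acid at this position would give a number apart from these. Also open, from the compounds shown here alone, is whether the same exchange reads alike on the configuration of compound 1.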